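Swapping the Aniline Ring on a Shared Core

The source may report more compounds than this note shows. Statements on the series, on what has been measured and on what is new or still open speak of the compounds shown alone.

Compound 1, `CC(=O)N1CCN(c2ccc(Nc3ncc(C(F)(F)F)c(N4Cc5cccc(N(C)S(C)(=O)=O)c5C4)n3)cc2)CC1`, gives 22100 nM in a functional assay on U-87MG ATCC cells for antiproliferative activity against U-87 MG (Homo sapiens), read by spectrophotometry, with a stated time of 2 days; a lower number here means a stronger inhibitor of growth, a higher number a weaker inhibitor of growth.
Compound 3, `CN(c1cccc2c1CN(c1nc(Nc3cccc(Oc4ccccc4)c3)ncc1C(F)(F)F)C2)S(C)(=O)=O`, gives 19500 nM in this assay.
Compound 2, `Cc1ccc(Nc2ncc(C(F)(F)F)c(N3Cc4cccc(N(C)S(C)(=O)=O)c4C3)n2)c(Cl)c1`, reaches only the limit of this assay, > 30000 nM.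

All three measured compounds share one core and differ only in the aromatic ring carried on the amine nitrogen. Compounds 1 and 3 are weak growth inhibitors, and their two values lie within the usual scatter of each other. Compound 2 stands apart in that no number exists for it at all: the limit of > 30000 nM in this assay, at which 1 of the 3 values shown sits, so it is only known to be at least as weak as that boundary.

The compound not yet measured is compound 4, `COc1cc(Nc2ncc(C(F)(F)F)c(N3Cc4cccc(N(C)S(C)(=O)=O)c4C3)n2)cc(C(F)(F)F)c1`. It arises from compound 2 by one change: 3-methoxy-5-(trifluoromethyl)phenyl in place of 2-chloro-4-methylphenyl on a nitrogen on an aromatic ring. Within the data shown here, no measured pair in this set differs in one place, so no measured step shows how such a swap of the aromatic ring shifts growth inhibition, and the size of the expected step in this assay is uncertain. Given that every measured compound is weak, compound 4 is expected to stay weak, with an estimated 25000 nM (range 8000 nM to 60000 nM). That estimate means an expected step of an at least 1.2-fold lower number from compound 2 to compound 4 (0.07 log units; that floor lies within the scatter), and there is a fair chance the assay again reports only a limit.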

Compound 4, concentration for 50% growth inhibition: > 30000 nM
Compound 4 gave a limit, no number; the forecaster's own chance of this, stated with the estimate: 45%; middle value at least 1.2-fold (0.07 log units) from the limit.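

Among these compounds, compound 2 and compound 4 both end at a limit of the assay and not at a number, so no step between them can be read: the limit of > 30000 nM in this assay, at which 2 of the 4 values shown sit.

The compounds shown leave open whether 3-methoxy-5-(trifluoromethyl)phenyl and 2-chloro-4-methylphenyl on this nitrogen differ at all in growth inhibition in this assay once the measurements go past that limit.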